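A few compounds are considered here, and "the series" means these few. Any claim that something is new, unique, unknown or untested is made for them only; others in the source may bear on it.

Measured compounds in a functional assay on MCF7 cells (Homo sapiens) for antiproliferative activity, read by MTT assay, with a stated time of 48 h; on this read-out lower numbers stand for stronger inhibition and higher numbers for weaker inhibition:

compound 1, `O=C1C=CC2(C=C1)OC(=O)C(c1cc3ccccc3s1)=C2c1ccccc1`, gives 5900 nM
compound 2, `COc1ccc(F)cc1C1=C(c2ccccc2)C2(C=CC(=O)C=C2)OC1=O`, gives 5730 nM
compound 3, `N#Cc1ccc(C2=C(c3ccccc3)C3(C=CC(=O)C=C3)OC2=O)cc1`, gives 19000 nM

All three share one core and differ only in the aryl group on a double-bonded ring carbon. Compound 3 carries the highest number of the three in this assay: the change a 3.2-fold higher number from compound 1 to compound 3 (0.51 log units; beyond the scatter) and the change a 3.3-fold higher number from compound 2 to compound 3 (0.52 log units; beyond the scatter) are both modest but beyond the scatter, whereas the change a 1.0-fold lower number from compound 1 to compound 2 (0.01 log units; within the scatter) is within it.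

Compound 4, `O=C1C=CC2(C=C1)OC(=O)C=C2c1ccccc1`, takes this one step further: hydrogen in place of 4-cyanophenyl on a double-bonded ring carbon. Going by the values given here, none of the measured steps removes the aryl group outright; they only exchange one aryl group for another, and those exchanges moved the number by little or by a modest amount. Among the compounds with values here, with no direct precedent, the expected step is a 1.2-fold higher number from compound 3 to compound 4 (0.06 log units; within the scatter), and the estimate for compound 4 is wide.

For compound 4 the expected value in this assay is 22000 nM, with a range from 6000 nM to 70000 nM.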

Compound 4, half-maximal inhibitory concentration: 6460 nM
The estimate for compound 4 lay 3.4-fold (0.53 log units) above the measured number; measured number inside the range.
By their numbers in this assay, from the lowest: compounds 2, 1 and 4 (each within the scatter of the next); then compound 3.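

Taking the aryl group off this double-bonded ring carbon altogether does not cost activity in this assay here, so compound 4 shows that no aryl group at this position is needed to reach numbers like those of compound 1 and compound 2. Hydrogen in place of 4-cyanophenyl gives a 2.9-fold lower number from compound 3 to compound 4 (0.47 log units; beyond the scatter) in this series, while the two other exchanges for hydrogen give a 1.1-fold higher number from compound 2 to compound 4 (0.05 log units; within the scatter) and a 1.1-fold higher number from compound 1 to compound 4 (0.04 log units; within the scatter) and so cannot be told apart from no change. Of the three aryl groups, only 4-cyanophenyl stands apart from hydrogen, and no measurement at hand explains this.

As far as these compounds go, what a small group such as methyl, an amine or a carboxylic acid would do at this carbon stays open. So does the role of the phenyl group on the ring atom that carries it.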